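Nitro in place of methoxy on the shared core

The source may report more compounds than this note shows. Statements on the series, on what has been measured and on what is new or still open speak of the compounds shown alone.

Measured in a functional assay on A549 cells (Homo sapiens) for antiproliferative activity, read by MTT assay, with a stated time of 72 h; on this read-out lower numbers stand for stronger inhibition and higher numbers for weaker inhibition:
- compound 1 `COc1cccc(/C=C/C(=O)/C=C/c2nc(C)c(C)nc2C)c1`: 3300 nM
- compound 2 `COc1ccc(/C=C/C(=O)/C=C/c2nc(C)c(C)nc2C)cc1OC`: 3790 nM

Not yet measured: compound 3 `Cc1nc(C)c(/C=C/C(=O)/C=C/c2cccc([N+](=O)[O-])c2)nc1C`

For the measured compounds named here, compound 1 has only one measured neighbour, and the two values lie within the scatter of each other, so compound 1 does not stand apart from compound 2.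

Compound 3 keeps the core of compound 1 and differs from it as follows: nitro in place of methoxy on an aromatic carbon. This is nitro in place of methoxy on an aromatic carbon, meta to a large group.

Going by the values given here, the only measured step is a 1.1-fold higher number from compound 1 to compound 2 (0.06 log units; within the scatter), which is methoxy in place of hydrogen on an aromatic carbon. That step bears on the new change only loosely, since it does not exchange methoxy for nitro. The data hold no direct measure of this exchange and give no direction for it. In this assay no step beyond the scatter is therefore expected, although the uncertainty is wide.

The estimated step is a 1.1-fold lower number from compound 1 to compound 3 (0.04 log units; within the scatter).

For compound 3 the estimated value is 3000 nM, with an expected range from 1200 nM to 7500 nM.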

Compound 3, half-maximal inhibitory concentration: 6700 nM
The estimate for compound 3 lay 2.2-fold (0.35 log units) below the measured number, within the range that was stated.
By their numbers in this assay, from the lowest: compounds 1, 2 and 3 (each within the scatter of the next, the first and the last beyond it).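

In this assay, the exchange of methoxy for nitro on this aromatic carbon, meta to a large group, gives a step beyond the scatter: a 2.0-fold higher number from compound 1 to compound 3 (0.31 log units; beyond the scatter). For the compounds shown here, the earlier step, methoxy in place of hydrogen, stayed within the scatter at a 1.1-fold higher number from compound 1 to compound 2 (0.06 log units; within the scatter), so this is the first sign that the substituent on the ring can shift the number, though the shift is modest and runs toward weaker inhibition. No measurement on hand bears on what lies behind this shift.

As far as these compounds go, a single exchange at one position gives no trend, so it remains open whether an amine, a chlorine atom or a carboxylic acid on the same carbon would stay close to methoxy or move the number as nitro does. From the compounds shown here alone, it is also open whether nitro would give a similar step on the core of compound 2, where the second methoxy is present.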